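Methyl in Place of Trifluoromethyl: An Expected Step Down

The compounds below may be only part of what the source reports. "The series", "measured", "known", "first", "only" and "open" are said of these compounds alone.

Of the compounds shown here, three built on one shared core have been measured in a functional assay on cells for positive allosteric modulation of G-protein coupled receptor 68 (Homo sapiens), read by a luciferase reporter and cAMP accumulation, with a stated time of 30 min, at pH 6.8 and pH 8.3, in the presence of a further agent that is not named here; a lower number here means a less potent compound, a higher number a more potent compound, by a factor of ten per unit of this negative logarithm. Compound 1 `Nc1nc(NCc2ccccc2F)nc(-c2ccccc2CO)n1` gives 4.27. Compound 2 `Nc1nc(NCc2ccc(F)cc2)nc(-c2ccccc2CO)n1` gives 3.97. Compound 3 `Nc1nc(NCc2cccc(C(F)(F)F)c2)nc(-c2ccccc2CO)n1` gives 5.11, the highest of the three numbers, standing beyond the scatter above compound 1 and further still above compound 2.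

The next compound, compound 4 `Cc1cccc(CNc2nc(N)nc(-c3ccccc3CO)n2)c1`, differs from compound 3 in one place: methyl in place of trifluoromethyl on an aromatic carbon. For the measured compounds named here, no measured step bears directly on this exchange. Going by the values given here, the only measured step, a number 0.30 log units lower from compound 1 to compound 2 (within the scatter), concerns where a fluorine sits and lies within the scatter, so it says nothing about trading a trifluoromethyl for a methyl. What the numbers do show is that compound 3, carrying the trifluoromethyl, stands beyond the scatter above compound 1 and compound 2, which carry fluorine instead. Among the compounds with values here, with no step on this change to draw on, the expectation can only lean on that gap. For compound 4 the step of a number 0.41 log units lower from compound 3 to compound 4 (beyond the scatter) is expected, towards the numbers given by the fluorine-bearing compounds but not all the way. Compound 4 is therefore estimated at 4.7, with a range from 4 to 5.4.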

Compound 4, negative logarithm of the antagonist equilibrium constant: 4.4
Estimate against measurement, compound 4: 0.30 log units above; measured number inside the range.
By their numbers in this assay, from the lowest: compounds 2, 1 and 4 (each within the scatter of the next, the first and the last beyond it); then compound 3.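

In this assay, for the compounds shown here, the exchange of trifluoromethyl for methyl on this aromatic carbon, meta to a large group, gives a number 0.71 log units lower from compound 3 to compound 4 (beyond the scatter) and is the first measured step at this position, showing that the number here depends on which of these two groups the carbon carries. Methyl does not hold the level of compound 3, and the new compound falls in with the fluorine-bearing compounds without matching both of them: the comparison gives a number 0.13 log units higher from compound 1 to compound 4 (within the scatter) on one side and a number 0.43 log units higher from compound 2 to compound 4 (beyond the scatter) on the other, and each of these two steps replaces a whole substituted phenyl, so neither isolates a single group at one place. The compounds shown offer no measurement that accounts for the size of the step from trifluoromethyl to methyl.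

From the compounds shown here alone, whether a chlorine, a methoxy group or a nitrile on this same aromatic carbon would stand with compound 3 or with compound 4 remains open. Also open is what an ethyl group or a longer chain in place of the methyl would give in this assay, as the compounds shown hold only these two groups at this position.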